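A few compounds are considered here, and "the series" means these few. Any claim that something is new, unique, unknown or untested is made for them only; others in the source may bear on it.

Working notes, cytotoxicity series.

Compound 2 `O=C(Nc1cccc(OCCc2ccccn2)c1)C1CCCN(C(=O)c2cc(C(F)(F)F)cc(C(F)(F)F)c2)C1` is the reference for the next step. Within the data shown here, in an ADME assay on PC-3 cells (Homo sapiens) for cytotoxicity, read by WST assay, tested at 100 uM (a lower number here means less inhibition, a higher number more inhibition at the concentration tested (going by the name of the read-out)), compound 2 gives 5%, which is the top of the three numbers measured so far, although the two others lie within the scatter of it: compound 1 `Cc1cccc(C(=O)N2CCCC(C(=O)Nc3ccc(Cl)cc3)C2)c1` gives 0% and compound 3 `O=C(c1ccccc1)c1cccc(C(=O)N2CCCC(C(=O)Nc3ccc(Cl)cc3)C2)c1` gives 0% in this assay. Among the measured compounds shown here, the single measured step, no change at the digits printed from compound 1 to compound 3 (within the scatter), concerns a different position of the shared core and a different kind of exchange, so it offers no direct guide here; it does show that a sizeable exchange on the aromatic carbon left the read-out unchanged.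

The change now considered is 1,3-oxazol-5-yl in place of 2-(pyridin-2-yl)ethoxy on an aromatic carbon, giving compound 4 `O=C(Nc1cccc(-c2cnco2)c1)C1CCCN(C(=O)c2cc(C(F)(F)F)cc(C(F)(F)F)c2)C1`. For the measured compounds named here, no measured step bears on this exchange. With all three known compounds at or near zero in this assay, and no movement beyond the scatter anywhere in the set, the expectation for compound 4 is no step beyond the scatter, a number 2 percentage points lower from compound 2 to compound 4 (within the scatter). Compound 4 is therefore estimated at 3% in this assay, within a range of 0% to 15%.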

Compound 4, a percentage reported as inhibition, at one concentration (the size of the read-out at that concentration, not a potency): 9%
The estimate for compound 4 lay 6 percentage points below the measured number, within the range that was stated.
By their numbers in this assay, from the lowest: compounds 1, 3, 2 and 4 (each within the scatter of the next).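

At this position, on an aromatic carbon meta to a large group, the exchange of 2-(pyridin-2-yl)ethoxy for 1,3-oxazol-5-yl gives a number 4 percentage points higher from compound 2 to compound 4 (within the scatter) in this assay. Among these compounds, this is the first measured exchange at this position, and it shows that going from 9 heavy atoms to 5, and from a six-membered to a five-membered aromatic ring, moves the read-out no further than the scatter. No available evidence bears on this result.

The compounds shown leave open whether an amine, a carboxylic acid or a longer alkoxy chain on this aromatic carbon would move the read-out beyond the scatter. They also leave open whether 1,3-oxazol-5-yl would behave the same way on the core of compound 1.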